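Adding a methyl to the core of compound 3

The source may hold more compounds than are shown below. What is called first, only, known or untested is meant among the compounds shown, and "the series" means these compounds.

Measured in a functional assay on K562 cells (Homo sapiens) for antiproliferative activity, read by MTT assay, with a stated time of 72 h; a lower number here means a stronger inhibitor, a higher number a weaker inhibitor:
Compound 1 `COc1ccc(-c2c(C(=O)c3cc(OC)c(OC)c(OC)c3)sc3ccccc23)cc1C` gives > 10000 nM as a limit of the assay
Compound 2 `COc1cc(C(=O)c2sc3ccccc3c2Nc2ccccc2)cc(OC)c1OC` gives 2300 nM
Compound 3 `CCOc1ccc(Nc2c(C(=O)c3cc(OC)c(OC)c(OC)c3)sc3ccccc23)cc1` gives 200 nM

Compound 3 holds the lowest number of the set, and the nearest number is compound 2, with a 12-fold lower number from compound 2 to compound 3 (1.06 log units; beyond the scatter) between them. The third value is a limit.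

Compound 4 `CCOc1ccc(Nc2c(C(=O)c3cc(OC)c(OC)c(OC)c3)sc3cc(C)ccc23)cc1` keeps everything in compound 3 except for one change on the shared core: methyl in place of hydrogen on an aromatic carbon.

Within the data shown here, no measured step covers this change. The closest in kind is the ethoxy in place of hydrogen behind a 12-fold lower number from compound 2 to compound 3 (1.06 log units; beyond the scatter), but it lies on another ring of the molecule and sets no size for a methyl on the core. The other two steps, an at least 4.3-fold lower number from compound 1 to compound 2 (0.63 log units; beyond the scatter) and an at least 50-fold lower number from compound 1 to compound 3 (1.69 log units; beyond the scatter), exchange a whole group and bear less on the question. Both of them start from a limit.

Among the measured compounds shown here, with no direct precedent, no step beyond the scatter is expected in this assay, although a sizeable move either way remains possible. The expected step is a 1.3-fold lower number from compound 3 to compound 4 (0.12 log units; within the scatter) and this is only a rough estimate. For compound 4 the estimated value is 150 nM, with an expected range of 30 nM to 700 nM.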

Compound 4, half-maximal inhibitory concentration: 4300 nM
Compound 4: the middle estimate sits 29-fold (1.46 log units) below what was measured; measured number above the stated range.
By their numbers in this assay, from the lowest: compound 3; then compounds 2 and 4 (each within the scatter of the next). At a limit, above all of these: compound 1.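

Methyl in place of hydrogen on the shared core, at the aromatic carbon that is meta to a fused ring and para to a fused ring, gives a 22-fold higher number from compound 3 to compound 4 (1.33 log units; beyond the scatter) in this assay. Among these compounds, the earlier steps all exchanged groups outside this six-membered aromatic ring, so this is the first reading on the ring itself, and it shows that the position is far from indifferent: a change of a single heavy atom here moves the number beyond the scatter. Only compound 1 is a limit rather than a number, while this new step rests on two measured values, so its size is not cut short by the assay: the limit of > 10000 nM in this assay, at which 1 of the 4 values shown sits.

One substituent at one carbon cannot show whether any group here raises the number or whether the loss is particular to methyl; fluoro, chloro, methoxy or hydroxy at the same carbon would separate those readings. Going by these compounds, it also stays open whether the other carbons of this ring respond in the same way, and whether the same methyl has a step of similar size with the anilino group of compound 2.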